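The source may hold more compounds than are shown below. What is called first, only, known or untested is meant among the compounds shown, and "the series" means these compounds.

Working notes on the series.

Compound 2, `CN1C[C@H](C(=O)Nc2ccc(C(F)(F)F)cc2)[C@@H](c2ccc(/C=C/C(=O)Nc3ccccc3N)cc2)C1`, is being used as the starting point for the next change. In an in vitro ADME assay on microsomes from liver (Mus musculus) for pharmacokinetics, read by LC-MS, with a stated time of 10 min, tested at 1 uM (on this read-out higher numbers stand for fast clearance and lower numbers for slow clearance), compound 2 gives 23 mL/min/kg. Within the data shown here, that is the lowest of the two numbers so far, though only just: the nearest is compound 1, `CN1C[C@H](C(=O)Nc2ccc(C#N)cc2)[C@@H](c2ccc(/C=C/C(=O)Nc3ccccc3N)cc2)C1`, which in this assay gives 35 mL/min/kg. Among the measured compounds shown here, the single measured step, a 1.5-fold lower number from compound 1 to compound 2 (0.18 log units; within the scatter), is the only comparison available and says nothing firm about direction.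

Compound 3, `CN1C[C@H](C(=O)Nc2ccc(Cl)cc2F)[C@@H](c2ccc(/C=C/C(=O)Nc3ccccc3N)cc2)C1`, differs from compound 2 in one place: 4-chloro-2-fluorophenyl in place of 4-(trifluoromethyl)phenyl on an amide-type nitrogen. For the measured compounds named here, no measured step touches the same aryl portion of the anilide in a way that resembles this swap; the one step on record changes only the group on that ring, and it sat within the scatter. There is therefore no basis to expect a shift in this assay beyond the usual spread in either direction, and the working expectation is a flat step.

The estimate for compound 3 is 25 mL/min/kg in this assay, with a range from 12 mL/min/kg to 50 mL/min/kg. The expected step from compound 2 to compound 3 is a 1.1-fold higher number from compound 2 to compound 3 (0.04 log units; within the scatter).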

Compound 3, clearance: 43 mL/min/kg
Compound 3: the middle estimate sits 1.7-fold (0.24 log units) below what was measured; the range from low to high includes it.
By their numbers in this assay, from the lowest: compounds 2, 1 and 3 (each within the scatter of the next).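

At the amide-type nitrogen, the whole aryl group can be exchanged, 4-chloro-2-fluorophenyl in place of 4-(trifluoromethyl)phenyl, and the read-out in this assay stays within the scatter (a 1.9-fold higher number from compound 2 to compound 3 (0.27 log units; within the scatter)). The same holds for the exchange from 4-cyanophenyl (a 1.2-fold higher number from compound 1 to compound 3 (0.09 log units; within the scatter)), so the earlier single comparison now has a second and third beside it, and a ring carrying both fluorine and chlorine cannot be told apart from a ring carrying trifluoromethyl or nitrile alone. Nothing on record bears on the reason for these numbers, and the three compounds show no measurable preference at this position in this assay.

The compounds shown leave open whether this position can move the read-out beyond the scatter at all, for instance with a carboxylic acid or a dimethylamino group on the aryl ring, or with cyclohexyl in place of the aryl group. They also leave open whether any of the three aryl groups would separate from the others on repeated measurement, or whether changes elsewhere on the shared core matter more than changes at this nitrogen.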